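Z to E at one double bond

The source may report more compounds than this note shows. Statements on the series, on what has been measured and on what is new or still open speak of the compounds shown alone.

Going by the values given here, compound 2 (`NC/C=C\CN(C[C@H]1Cc2ncccc2CN1)[C@H]1CCCc2cccnc21`) is one of two compounds measured so far in an ADME assay on microsomes from liver (Rattus norvegicus) for metabolic stability, using NADPH, with a stated time of 10 min (on this read-out lower numbers stand for a less stable compound and higher numbers for a more stable compound), and holds the lower number of the pair. In this assay compound 2 gives 11% while compound 1 (`NCCCCN(C[C@@H]1Cc2nccnc2CN1)[C@H]1CCCc2cccnc21`) gives 67% in the same test, a gap beyond the scatter.

Compound 3 (`NC/C=C/CN(C[C@H]1Cc2ncccc2CN1)[C@H]1CCCc2cccnc21`) has not yet been measured. The comparison with compound 2 reads as follows: the two compounds have the same atoms and bonds and differ only in configuration as drawn: 1 of 3 stereo elements differ; a double bond is drawn Z in compound 2 and E in compound 3 (a double bond is drawn Z in compound 2 and E in compound 3). Among the compounds with values here, no measured pair here shows the size of such a change, and the data offer no direct precedent for it. Compound 3 shares its atoms and bonds with compound 2, so the 11% of compound 2 is the starting point for the expectation. The expected size of a number 4 percentage points higher from compound 2 to compound 3 (within the scatter) in this assay is small and upward, within the scatter, although a larger rise cannot be excluded. The estimated value for compound 3 is 15% with an expected range from 4% to 35% for repeated measurements.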

Compound 3, percent of the compound remaining: 11%
Estimate against measurement, compound 3: 4 percentage points above, and the stated range covers the measured number.
By their numbers in this assay, from the lowest: compounds 2 and 3 (each within the scatter of the next); then compound 1.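

In this assay, turning the one double bond in the chain from Z to E gives no change at the digits printed from compound 2 to compound 3 (within the scatter), so at this position the geometry drawn at that bond leaves the read-out where it stood, and both compounds stay at the low end of the three numbers shown. Going by these compounds alone, this is the first pair in the set that can be read as a single change, since the earlier two compounds differ in more than one place and could not be set against each other step by step. The step can therefore be tied to the double bond alone and to nothing else in the structure: the fact that compounds 2 and 3 differ only in the configuration as drawn

The compounds shown leave open whether the double bond itself has any bearing on the read-out, since no pair sets either form against a chain without a double bond on this same core, and the number for compound 1 cannot be traced to any one of the places where it differs from compound 2. A triple bond in the chain, a longer chain, or an amide in place of the amine would each have to be read on this core before anything could be said about that part of the molecule.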